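Trading a Methoxyphenyl for a Furan on the Dienone

The compounds below may be only part of what the source reports. "The series", "measured", "known", "first", "only" and "open" are said of these compounds alone.

Compound 1 `COc1ccccc1/C=C/C(=O)/C=C/c1ccc(OCc2cn(CCOc3cc(=O)oc4ccccc34)nn2)c(OC)c1` is the strongest of the three measured compounds in a functional assay on COLO 205 cells (Homo sapiens) for inhibition, read by sulforhodamine B assay, with a stated time of 48 h, tested at 50 uM (a higher number here means more inhibition of growth at the concentration tested, a lower number less inhibition of growth), where compound 1 gives 67%. Compound 3 `COc1cccc(/C=C/C(=O)/C=C/c2ccc(OCc3cn(CCCOc4cc(=O)oc5ccccc45)nn3)c(OC)c2)c1` gives 52% in this assay, and compound 2 `COc1cc(/C=C/C(=O)/C=C/c2ccco2)ccc1OCc1cn(CCCCCOc2cc(=O)oc3ccccc23)nn1` gives 33%; both of these lie beyond the scatter below compound 1. Compound 4 `COc1cc(/C=C/C(=O)/C=C/c2ccco2)ccc1OCc1cn(CCOc2cc(=O)oc3ccccc23)nn1` has not been measured. It differs from compound 1 in one place: furan-2-yl in place of 2-methoxyphenyl on a double-bonded chain carbon bound to a double-bonded chain carbon. Going by the values given here, no pair of measured compounds shows exactly this change on its own. A drop is nevertheless expected because compound 2 gives 33% while also carrying a furan-2-yl, although compound 2 differs elsewhere as well. The estimated step is a number 19 percentage points lower from compound 1 to compound 4 (beyond the scatter). Compound 4 is therefore expected to give 48% in this assay, within a range from 33% to 63%.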

Compound 4, percent growth inhibition at one concentration: 68%
Compound 4: middle estimate off by 20 percentage points, on the low side, and the stated range ends below it.
By their numbers in this assay, from the lowest: compound 2; then compound 3; then compounds 1 and 4 (each within the scatter of the next).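

In this assay, the five-membered furan-2-yl can replace the six-membered 2-methoxyphenyl at this position with a number 1 percentage points higher from compound 1 to compound 4 (within the scatter), so this swap on its own leaves no detectable change. Furan-2-yl therefore does not by itself bring a low number, since compound 4 carries it as well as compound 2 does.

Going by these compounds, whether this tolerance extends to a ring bearing an amine or a carboxylic acid at this position remains open. Nothing measured here explains why the two groups read alike.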